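Swapping a Hydroxypropyl for a Thiazole on the Amide Nitrogen

The source may hold more compounds than are shown below. What is called first, only, known or untested is meant among the compounds shown, and "the series" means these compounds.

Measured so far:
- compound 1, `CCN(Cc1ccoc1)C(=O)COc1ccc(C)cc1`, 136 nM
- compound 2, `Cc1ccc(OCC(=O)N(CCCO)Cc2cccs2)cc1`, 3000 nM
- compound 3, `CCN(Cc1cccs1)C(=O)COc1ccc2c(c1)CCCC2`, 689 nM

These three share an aryloxyacetamide core and were tested in an assay on HEK293 cells for agonist activity at transient receptor potential cation channel subfamily M member 8 (Homo sapiens), read by fluorescence and calcium flux, with a stated time of 15 min; on this read-out higher numbers stand for an effect only at larger amounts of compound and lower numbers for an effect already at smaller amounts. Compound 2 gives the highest number of the three, so it is the weakest agonist here, with compound 3 nearest and compound 1 furthest, both gaps beyond the scatter. Compound 4, `Cc1ccc(OCC(=O)N(Cc2cccs2)c2nccs2)cc1`, has not been measured; it differs from compound 2 in one place: 1,3-thiazol-2-yl in place of 3-hydroxypropyl on an amide-type nitrogen. Among the measured compounds shown here, no measured pair shows this change, and compounds 1 and 3 carry an ethyl rather than a hydroxypropyl at that nitrogen, so the direction is uncertain. A gain in potency is expected, of size a 5.0-fold lower number from compound 2 to compound 4 (0.70 log units; beyond the scatter). Compound 4 is estimated at 600 nM, within 120 nM to 3000 nM.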

Compound 4, half-maximal effective concentration: 2240 nM
Beside the measured number, compound 4's estimate is 3.7-fold (0.57 log units) below it, within the range that was stated.
By their numbers in this assay, from the lowest: compound 1; then compound 3; then compounds 4 and 2 (each within the scatter of the next).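

In this assay, putting 1,3-thiazol-2-yl in place of 3-hydroxypropyl on the amide-type nitrogen gives a 1.3-fold lower number from compound 2 to compound 4 (0.13 log units; within the scatter), a step within the scatter. The two numbers therefore cannot be told apart, even though an open chain carrying a hydrogen-bond donor gives way to a five-membered aromatic ring with none. Nothing measured here explains this result.

What the compounds shown leave open is whether a phenyl ring, a longer chain or a chain ending in a carboxylic acid on this nitrogen would give a different number.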